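The compounds below may be only part of what the source reports. "The series", "measured", "known", "first", "only" and "open" are said of these compounds alone.

Measured so far:
- compound 1 `CC(C)CCC(=O)Nc1c(C(O)(C(F)(F)F)C(F)(F)F)ccc2ccccc12`: 49 nM
- compound 2 `O=C(Nc1c(C(O)(C(F)(F)F)C(F)(F)F)ccc2ccccc12)c1cccc([N+](=O)[O-])c1`: 117 nM

Compound 1 gives the lowest of the two numbers in an assay on LtK cells with ATP-sensitive inward rectifier potassium channel 11 (Homo sapiens) as the target; on this read-out lower numbers stand for an effect already at smaller amounts and higher numbers for an effect only at larger amounts of compound; its nearest neighbour is compound 2, and a 2.4-fold higher number from compound 1 to compound 2 (0.38 log units; beyond the scatter), a modest step, where the change is 3-nitrophenyl in place of isopentyl on a carbonyl carbon. The unmeasured compound 3 `O=C(Nc1c(C(O)(C(F)(F)F)C(F)(F)F)ccc2ccccc12)c1ccc(F)cc1` differs from compound 1 in a related way: 4-fluorophenyl in place of isopentyl on a carbonyl carbon. Within the data shown here, the only measured step that bears on this is the one from compound 1 to compound 2, since both replace the isopentyl chain with a six-membered aromatic ring on the same carbonyl carbon. A step of similar direction, and of roughly that size or a little smaller, is therefore expected for compound 3 in this assay, though a fluorine differs from a nitro group and the expectation stays loose. For compound 3 the expected step is a 1.8-fold higher number from compound 1 to compound 3 (0.26 log units; within the scatter), giving an estimate of 90 nM with a range from 40 nM to 200 nM.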

Compound 3, half-maximal effective concentration: 70 nM
The estimate for compound 3 lay 1.3-fold (0.11 log units) above the measured number; the range from low to high includes it.
By their numbers in this assay, from the lowest: compounds 1, 3 and 2 (each within the scatter of the next, the first and the last beyond it).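

In this assay, the aromatic ring of compound 3 is tolerated at this carbonyl carbon about as well as the isopentyl chain (a 1.4-fold higher number from compound 1 to compound 3 (0.15 log units; within the scatter)), so an aromatic ring here need not cost anything measurable. The 4-fluorophenyl and 3-nitrophenyl rings also cannot be told apart (a 1.7-fold lower number from compound 2 to compound 3 (0.22 log units; within the scatter)), so compound 3 falls within the scatter of both other compounds, even though the gap between those two lies beyond it. No measurement shown here explains these small differences.

On these data alone, it remains open whether a plain phenyl ring, a ring carrying an amine or a carboxylic acid, or a longer chain at this carbonyl carbon would stay in the same range. As far as these compounds go, all three compounds share one core, so the effect of changes elsewhere in the core of compound 1 also remains unknown.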